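Sulfonyl aryl variation in an aryl sulfone agonist series

The source may hold more compounds than are shown below. What is called first, only, known or untested is meant among the compounds shown, and "the series" means these compounds.

Measured so far, in a functional assay on HeLa cells for agonist activity at 5-hydroxytryptamine receptor 6 (Homo sapiens), read by cAMP accumulation and immunoassay; a higher number here means that more compound is needed for the effect, a lower number that less compound is needed:
compound 1 `O=S(=O)(c1cccc(F)c1)c1cn(C2CCNC2)c2ncccc12` gives 278 nM
compound 2 `O=S(=O)(c1ccc(F)cc1)c1cn(C2CCNC2)c2ncccc12` gives 1650 nM
compound 3 `O=S(=O)(c1ccccc1)c1cn(C2CCCNC2)c2ncccc12` gives 47 nM

Compound 3 has the lowest number of the three, beyond the scatter against both others. The next compound, compound 4 `O=S(=O)(c1cc(Cl)cc(Cl)c1)c1cn(C2CCCNC2)c2ncccc12`, carries 3,5-dichlorophenyl in place of phenyl on a sulfonyl sulfur. For the measured compounds named here, the only step touching the aryl group on the sulfonyl sulfur is a 5.9-fold higher number from compound 1 to compound 2 (0.77 log units; beyond the scatter), showing that where a halogen sits on that ring matters at a modest scale; no step here goes from an unsubstituted to a substituted ring. Compound 4 is therefore expected to move by a modest amount, direction uncertain, most likely a 1.9-fold higher number from compound 3 to compound 4 (0.28 log units; within the scatter). The estimate for compound 4 in this assay is 90 nM, with a range from 20 nM to 400 nM.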

Compound 4, half-maximal effective concentration: 297 nM
Compound 4: the middle estimate sits 3.3-fold (0.52 log units) below what was measured; low and high end bracket the measured number.
By their numbers in this assay, from the lowest: compound 3; then compounds 1 and 4 (each within the scatter of the next); then compound 2.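

For the compounds shown here, with the core of compound 3 held fixed, this is the first step from an unsubstituted ring to a substituted one on the sulfonyl sulfur: in this assay, 3,5-dichlorophenyl in place of phenyl gives a 6.3-fold higher number from compound 3 to compound 4 (0.80 log units; beyond the scatter). Substitution on this ring is therefore not neutral on this core, and phenyl needs less compound than 3,5-dichlorophenyl. Nothing available explains the rise.

Going by these compounds, whether a single chlorine would produce a step of the same size remains open. So does how a methoxy group or a nitrile on this ring would compare with phenyl on this core.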